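The source may hold more compounds than are shown below. What is called first, only, known or untested is meant among the compounds shown, and "the series" means these compounds.

Measured compounds:

- Compound 1, `Cc1cccc(-n2nncc2CN2C(=O)C3(C(C#N)=C(N)Oc4c(N)cc5nc6ccccc6nc5c43)c3ccccc32)c1`, is reported only as a limit in an ADME assay on L02 cells (Homo sapiens) for antiproliferative activity, read by MTT assay, with a stated time of 48 h (on this read-out lower numbers stand for stronger inhibition and higher numbers for weaker inhibition), namely > 50000 nM.
- Compound 2, `COc1ccccc1-n1nncc1CN1C(=O)C2(C(C#N)=C(N)Oc3c(N)cc4nc5ccccc5nc4c32)c2ccccc21`, is likewise reported only as a limit, > 50000 nM.
- Compound 3, `CCOc1ccc(-n2nncc2CN2C(=O)C3(C(C#N)=C(N)Oc4c(N)cc5nc6ccccc6nc5c43)c3ccccc32)cc1`, is again reported only as a limit, > 50000 nM.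

Compound 3 thus stands nowhere on a number scale: its result is a limit of the method, and the same holds for the two compounds beside it, so that (the limit of > 50000 nM in this assay, at which 3 of the 3 values shown sit). The steps among them, a step that the two limits leave unreadable from compound 1 to compound 2, a step that the two limits leave unreadable from compound 1 to compound 3 and a step that the two limits leave unreadable from compound 2 to compound 3, cannot be sized.

Compound 4, `N#CC1=C(N)Oc2c(N)cc3nc4ccccc4nc3c2C12C(=O)N(Cc1cnnn1-c1ccc(Cl)cc1Cl)c1ccccc12`, differs from compound 3 by 2,4-dichlorophenyl in place of 4-ethoxyphenyl on an aromatic nitrogen. All three measured steps bear on this change, since each swaps the group on the same aromatic nitrogen, but none of them yields a readable size. No shift beyond the scatter is therefore expected, and the most likely outcome is another limit.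

Compound 4 is expected to give about 60000 nM, in a range from 30000 nM to 200000 nM. The expected step is a step that the limit leaves unreadable from compound 3 to compound 4.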

Compound 4, half-maximal inhibitory concentration: > 50000 nM
Compound 4: only a limit was reported (the forecaster's own chance of this, stated with the estimate: 85%); the middle value lies beyond the limit too.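

Among the compounds shown here, compound 4 is also reported only as a limit, so no step linking it to compound 1, compound 2 or compound 3 can be read: the limit of > 50000 nM in this assay, at which 4 of the 4 values shown sit. The compounds shown leave open how far beyond that limit each one lies and whether any group on the aromatic nitrogen would give a measurable value in this assay.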